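Switching an Ethyl for a Methoxycyclohexyl on an Amide

This account rests on a few compounds, and the source may have more. Where it says the series, first, only, none or still open, it means among the compounds named here.

Measured compounds:
- compound 1, `CNC(=O)c1cc(C(=O)N[C@H]2CC[C@H](O)CC2)c([C@@H](C)c2ccccc2Cl)o1`: 3.1
- compound 2, `CNC(=O)c1cc(C(=O)NC2CC2)cn(Cc2cccc3[nH]ccc23)c1=O`: 2.9
- compound 3, `CCNC(=O)c1cc(C(=O)NC)nn1[C@@H](C)c1ccccc1`: 3.7

Of the compounds shown here, three have been measured in a physicochemical assay for lipophilicity; on this read-out lower numbers stand for lower lipophilicity and higher numbers for higher lipophilicity. Compound 1 gives 3.1 and compound 2 gives 2.9; these two numbers sit within the usual scatter of each other, so no order can be read between them. Compound 3 gives 3.7, the highest of the three, and its gap to each of the other two lies beyond the scatter.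

The next compound, compound 4, `CNC(=O)c1cc(C(=O)N[C@H]2CC[C@H](OC)CC2)n([C@@H](C)c2ccccc2)n1`, is built from compound 3 by a single change on the amide-type nitrogen whose other neighbour is a carbonyl carbon: 4-methoxycyclohexyl in place of ethyl on an amide-type nitrogen. Going by the values given here, no pair of measured compounds shows this change in isolation, so there is no measured step to lean on; the expectation rests on compound 3 alone. A step upward, well beyond the scatter, is expected in this assay, as a number 0.70 log units higher from compound 3 to compound 4 (beyond the scatter). Compound 4 is thus estimated at 4.4, with a likely range from 3.7 to 5.1.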

Compound 4, distribution coefficient: 4.2
Beside the measured number, compound 4's estimate is 0.20 log units above it; low and high end bracket the measured number.
By their numbers in this assay, from the lowest: compounds 2 and 1 (each within the scatter of the next); then compound 3; then compound 4.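

In this assay, going by these compounds alone, putting 4-methoxycyclohexyl in place of ethyl on the amide-type nitrogen gives a number 0.50 log units higher from compound 3 to compound 4 (beyond the scatter) and is the only step here between compounds that differ in one place. It shows that this position responds to the change: the read-out goes up even though the entering group, with 8 heavy atoms against 2, includes an oxygen that counts as a hydrogen-bond acceptor. No measurement shown here explains the size of this step.

Going by these compounds, the ring and the methoxy group enter together, so their separate shares of the step remain open, and a plain cyclohexyl on this nitrogen would help to tell them apart. Also open, on these data alone, is whether the same change would give a similar step on another core, or how a ring carrying an amine would compare at this position.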